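The compounds below may be only part of what the source reports. "The series", "measured", "known", "first", "only" and "open" are said of these compounds alone.

In a functional assay on MCF cells (Homo sapiens) for antiproliferative activity, with a stated time of 72 h (a lower number here means a stronger inhibitor, a higher number a weaker inhibitor), compound 1 (`OC[C@H]1O[C@@H](n2cnc3c(NCc4ccc(Br)cc4)ncnc32)[C@H](O)[C@@H]1O`) shows only a limit of the assay (> 166000 nM) and no number. Compound 2 (`COc1cccc(CNc2ncnc3c2ncn3[C@@H]2O[C@H](CO)[C@@H](O)[C@H]2O)c1OC`) also stands at a limit (> 166000 nM), so it has no readable potency to start from. Compound 3 (`OC[C@H]1O[C@@H](n2cnc3c(NCc4c(F)ccc(F)c4F)ncnc32)[C@H](O)[C@@H]1O`) carries 2,3,6-trifluorophenyl in place of 2,3-dimethoxyphenyl on a saturated chain carbon bound to a nitrogen on an aromatic ring. Within the data shown here, the one measured step bearing on this is also an aryl exchange at that place (a step that the two limits leave unreadable from compound 1 to compound 2), and it gives no size. All the evidence sits at one ceiling (the limit of > 166000 nM in this assay, at which 2 of the 2 values shown sit), so nothing supports a gain in this assay, and the expected outcome is no real movement (a step that the limit leaves unreadable from compound 2 to compound 3). The estimated value for compound 3 is (170000 nM), with an expected range from (60000 nM) to (400000 nM), and another limit is the likeliest report.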

Compound 3, half-maximal inhibitory concentration: > 166000 nM
Compound 3: no number, only a limit; the forecaster's own chance of this, stated with the estimate: 80%; the middle value lies beyond the limit too.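

In this assay, among these compounds, compound 3 gives only a limit, > 166000 nM, so no step from compound 1 or compound 2 to compound 3 can be read. The compounds shown leave open whether any aryl group at this place would give a readable value in this assay.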